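Pyrazoline series: acyl variant of the dichlorophenyl analogue

The source may report more compounds than this note shows. Statements on the series, on what has been measured and on what is new or still open speak of the compounds shown alone.

Compound 3 `COc1ccc(C2=NN(C(=O)CBr)C(c3ccco3)C2)cc1OC` gives 38% in a functional assay on the whole organism (strain albino) for inhibition, with Rattus norvegicus as the target, read by paw edema, with stated times of 30 min and 1 h, at a dose of 100 mg/kg by the oral route (on this read-out lower numbers stand for less inhibition and higher numbers for more inhibition at the one dose given (going by the name of the read-out)), and stands second highest of the three numbers; its nearest neighbour, compound 1 `COc1ccc(C2=NNC(c3ccco3)C2)cc1OC`, gives 45%, a gap within the scatter, while the furthest, compound 2 `COc1ccc(C2=NNC(c3c(Cl)cccc3Cl)C2)cc1OC`, gives 26%, a gap beyond the scatter. Going by the values given here, the one step measured in one place, a number 7 percentage points lower from compound 1 to compound 3 (within the scatter), concerns the acyl group and not the change now in hand. Compound 4 `COc1ccc(C2=NN(C(=O)CBr)C(c3c(Cl)cccc3Cl)C2)cc1OC` differs from compound 3 as 2,6-dichlorophenyl in place of furan-2-yl on a saturated ring carbon. Among the compounds with values here, no step of this kind is measured with the acyl group present; the same replacement without it is seen in compound 1 and compound 2, where compound 2 gives the lower number by a margin that exceeds the usual scatter. A drop of comparable size is therefore expected, a number 18 percentage points lower from compound 3 to compound 4 (beyond the scatter), on the assumption that the acyl group leaves the effect of the aryl swap unchanged. Compound 4 is accordingly estimated at 20%, with a likely range from 8% to 32%.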

Compound 4, a percentage reported as inhibition, in the whole organism at one dose (the size of the read-out at that dose, not a potency): 48%
Beside the measured number, compound 4's estimate is 28 percentage points below it; the measured number lies above the stated range.
By their numbers in this assay, from the lowest: compound 2; then compounds 3, 1 and 4 (each within the scatter of the next).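

In this assay, the group on the saturated ring carbon does not read the same with and without the acyl group: without it, compound 1 gives 45% and compound 2 gives 26%, whereas with it the swap to 2,6-dichlorophenyl gives a number 10 percentage points higher from compound 3 to compound 4 (within the scatter). Placing (bromomethyl)carbonyl on the amine nitrogen in the ring gives a number 22 percentage points higher from compound 2 to compound 4 (beyond the scatter), the first step of this change that lies beyond the scatter. The two changes therefore do not add independently across these four compounds, and the outcome of the acyl change depends on the group on the saturated ring carbon: the same change on two cores in this assay, a number 7 percentage points lower (within the scatter) from compound 1 to compound 3 and a number 22 percentage points higher (beyond the scatter) from compound 2 to compound 4, 29 percentage points apart, beyond the scatter of two such steps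

Going by these compounds alone, this rests on only two aryl groups and one acyl group. From the compounds shown here alone, whether the dependence extends to an acetyl group on the ring nitrogen, or to an unsubstituted phenyl on the saturated ring carbon, stays open.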